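The compounds below may be only part of what the source reports. "The series", "measured", "known", "first", "only" and "open" are said of these compounds alone.

Measured so far in an ADME assay on Caco-2 cells (Homo sapiens) for permeability, in the apical to basolateral direction; a higher number here means that the compound crosses the layer faster, a lower number that the compound crosses the layer more slowly:
compound 1 `Cn1nc2c(=O)n(CC3(O)CCN(Cc4ccc(-c5ccco5)cc4Cl)CC3)cnc2c1-c1ccc(CNCCO)cc1` gives 0.36 10^-6 cm/s
compound 2 `Cn1nc2c(=O)n(CC3(O)CCN(Cc4ccc(-c5cccs5)cc4Cl)CC3)cnc2c1-c1ccc(CN)cc1` gives 0.8 10^-6 cm/s

Compound 2 holds the higher of the two numbers in this assay; compound 1 stands a step lower that lies beyond the scatter. Within the data shown here, the two structures differ in more than one place, so no single step between them can be read, and the pair is noted only for what its two values show.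

Compound 3 `Cn1nc2c(=O)n(CC3(O)CCN(Cc4ccc(C5=CCCC5)cc4Cl)CC3)cnc2c1-c1ccc(CN)cc1` is the next compound due in this assay. It differs from compound 2 in one place: cyclopent-1-en-1-yl in place of thiophen-2-yl on an aromatic carbon. Both the leaving group and the entering group are five-membered rings sitting on the same aromatic carbon. Among the measured compounds shown here, no measured step of this kind exists. The expected step is a 1.3-fold higher number from compound 2 to compound 3 (0.10 log units; within the scatter), none beyond the scatter in either direction. Compound 3 is therefore estimated at 1 10^-6 cm/s, with a range from 0.4 10^-6 cm/s to 2.5 10^-6 cm/s.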

Compound 3, apparent permeability: 0.23 10^-6 cm/s
Compound 3: middle estimate off by 4.3-fold (0.64 log units), on the high side, and the stated range ends above it.
By their numbers in this assay, from the lowest: compounds 3 and 1 (each within the scatter of the next); then compound 2.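

In this assay, among these compounds, a 3.5-fold lower number from compound 2 to compound 3 (0.54 log units; beyond the scatter) is the first step that can be read at this position, on the aromatic carbon para to a large group. Thiophen-2-yl and cyclopent-1-en-1-yl both have 5 heavy atoms, so a matching heavy-atom count does not keep the number within the scatter here. The two groups differ in several ways at once (aromatic against non-aromatic ring, sulfur against carbon only, one hydrogen-bond acceptor against none), and no measurement in hand explains the step.

Still open, as far as these compounds go, is how a phenyl ring or a saturated cyclopentyl group would read at this place in this assay, with the rest of compound 2 held fixed. The furan-2-yl group of compound 1 offers no direct reading, as compound 1 differs from compound 2 in more than one place.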